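This account rests on a few compounds, and the source may have more. Where it says the series, first, only, none or still open, it means among the compounds named here.

In a functional assay on MDA-MB-468 cells (Homo sapiens) for cytotoxicity, read by trypan blue exclusion, with a stated time of 48 h (a higher number here means a weaker inhibitor, a lower number a stronger inhibitor), compound 1 `Cc1ccccc1OCC(=O)Nc1nc(-c2ccc(Cl)cc2)cs1` gives 52100 nM, the lowest of the two numbers recorded, and the nearest is compound 2 `CC(C)c1ccccc1OCC(=O)Nc1nc(-c2ccc(Cl)cc2)cs1`, which gives 55500 nM. Going by the values given here, the only measured step, a 1.1-fold higher number from compound 1 to compound 2 (0.03 log units; within the scatter), lies within the scatter, so changing the substituent on this ring has so far left this assay unmoved. Compound 3 `Cc1ccc(OCC(=O)Nc2nc(-c3ccc(Cl)cc3)cs2)cc1` differs from compound 1 by 4-methylphenyl in place of 2-methylphenyl on an oxygen on a saturated carbon. Among the compounds with values here, no measured pair shows this exact change, but the one step that touches the same ring, a 1.1-fold higher number from compound 1 to compound 2 (0.03 log units; within the scatter), was within the scatter, and this is taken as the best guide. The step of a 1.0-fold lower number from compound 1 to compound 3 (0.00 log units; within the scatter) is therefore expected to stay within the scatter, with no direction favoured. For compound 3 the estimate in this assay is 52000 nM, in a range from 25000 nM to 110000 nM.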

Compound 3, half-maximal inhibitory concentration: 50100 nM
Estimate against measurement, compound 3: 1.0-fold (0.02 log units) above; measured number inside the range.
By their numbers in this assay, from the lowest: compounds 3, 1 and 2 (each within the scatter of the next).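

With 4-methylphenyl in place of 2-methylphenyl on an oxygen on a saturated carbon, this assay shows a 1.0-fold lower number from compound 1 to compound 3 (0.02 log units; within the scatter). The earlier step, a 1.1-fold higher number from compound 1 to compound 2 (0.03 log units; within the scatter), changed the size of the alkyl group at one place on the ring, whereas this one keeps the methyl and changes where it sits, and this too leaves the number within the scatter. Across compounds 1, 2 and 3, neither kind of change to this ring has therefore moved the assay, though no information is available to explain why.

The compounds shown carry only methyl and isopropyl on this ring, so it remains open whether an amine or a carboxylic acid there would move the number. Also open, from the compounds shown here alone, is whether a longer chain in place of the oxygen-linked methylene would do so.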